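Compound 4: chloro in place of fluoro

The source may hold more compounds than are shown below. What is called first, only, known or untested is meant among the compounds shown, and "the series" means these compounds.

In a functional assay on MCF7 cells (Homo sapiens) for antiproliferative activity, read by MTT assay, with a stated time of 48 h (on this read-out lower numbers stand for stronger inhibition and higher numbers for weaker inhibition), compound 1 `O=C(/C=C/c1ccc2c(c1)OCCO2)NS(=O)(=O)c1ccccc1` gives 2.16 ug/mL. Compound 2 `Cc1ccc(S(=O)(=O)NC(=O)/C=C/c2ccc3c(c2)OCCO3)cc1` reaches only a limit of the assay, > 100 ug/mL. Compound 3 `O=C(/C=C/c1ccc2c(c1)OCCO2)NS(=O)(=O)c1ccc(F)cc1` gives 52.1 ug/mL, the higher of the two exact numbers in the series. Compound 4 `O=C(/C=C/c1ccc2c(c1)OCCO2)NS(=O)(=O)c1ccc(Cl)cc1` carries chloro in place of fluoro on an aromatic carbon, para to a large group (chloro in place of fluoro on an aromatic carbon). Replacing hydrogen gave two large steps, an at least 46-fold higher number from compound 1 to compound 2 (1.66 log units; beyond the scatter) and a 24-fold higher number from compound 1 to compound 3 (1.38 log units; beyond the scatter). Exchanging one substituent for another gave an at least 1.9-fold lower number from compound 2 to compound 3 (0.28 log units; that floor lies within the scatter), a floor within the scatter. No step beyond the scatter is therefore expected in this assay, and the estimated change is a 1.2-fold higher number from compound 3 to compound 4 (0.06 log units; within the scatter). Compound 4 is estimated at 60 ug/mL, with an expected range of 15 ug/mL to 130 ug/mL.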

Compound 4, half-maximal inhibitory concentration: 51.3 ug/mL
Compound 4: middle estimate off by 1.2-fold (0.07 log units), on the high side, within the range that was stated.
By their numbers in this assay, from the lowest: compound 1; then compounds 4 and 3 (each within the scatter of the next). At a limit, above all of these: compound 2.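

At this position the 4-fluorophenyl to 4-chlorophenyl exchange gives a step within the scatter, and the two halogens cannot be told apart here (a 1.0-fold lower number from compound 3 to compound 4 (0.01 log units; within the scatter)). Chloro, like fluoro, stands well above the hydrogen of compound 1 (a 24-fold higher number from compound 1 to compound 4 (1.38 log units; beyond the scatter)). The step from compound 2 gives only a floor within the scatter (an at least 1.9-fold lower number from compound 2 to compound 4 (0.28 log units; that floor lies within the scatter)), and it cannot be read further, the value of compound 2 being a limit of the assay: the limit of > 100 ug/mL in this assay, at which 1 of the 4 values shown sits.

As far as these compounds go, whether a methoxy group or an amine at this position would stay near compound 1 remains open. So does the effect of chloro on another carbon of this ring.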